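The source may report more compounds than this note shows. Statements on the series, on what has been measured and on what is new or still open speak of the compounds shown alone.

Of the compounds shown here, three that share one core have been tested in an ADME assay on HCT-116 cells (Homo sapiens) for cytotoxicity, read by CellTiter-Glo, with a stated time of 72 h; a lower number here means a stronger inhibitor, a higher number a weaker inhibitor. Compound 1 (`CC1CCN(C2CCN(S(=O)(=O)c3ccc(C(C)C)cc3)CC2)CC1`), with isopropyl on the aromatic ring, gives > 5000 nM, which is a limit of the assay. Compound 2 (`CCCCOc1ccc(S(=O)(=O)N2CCC(N3CCC(C)CC3)CC2)cc1`), with butoxy there, gives > 5000 nM, again a limit. Compound 3 (`COC(=O)c1ccc(S(=O)(=O)N2CCC(N3CCC(C)CC3)CC2)cc1`), with methoxycarbonyl there, gives > 5000 nM, also a limit. Compound 3 therefore stands with the other two at the limit of > 5000 nM in this assay, at which 3 of the 3 values shown sit, and no number separates them.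

Compound 4 (`CC1CCN(C2CCN(S(=O)(=O)c3ccc(C(C)(C)C)cc3)CC2)CC1`) carries tert-butyl in place of methoxycarbonyl on an aromatic carbon, para to a large group (tert-butyl in place of methoxycarbonyl on an aromatic carbon). Three measured steps exchange groups on an aromatic carbon in the same way: a step that the two limits leave unreadable from compound 1 to compound 2, a step that the two limits leave unreadable from compound 1 to compound 3 and a step that the two limits leave unreadable from compound 2 to compound 3. None of them has a readable size, so they give no measured size or direction to carry over. What they do show is that all three groups leave this assay at its limit, so no clear step is expected, and compound 4 is expected to read as a limit too. The expected change is a step that the limit leaves unreadable from compound 3 to compound 4. For compound 4 the estimate is 7000 nM, with an expected range from 2500 nM to 20000 nM.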

Compound 4, half-maximal inhibitory concentration: > 5000 nM
Compound 4: no number, only a limit; the forecaster's own chance of this, stated with the estimate: 80%; the middle value does not contradict the limit.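

For the compounds shown here, no step from compound 1, compound 2 or compound 3 to compound 4 can be read in this assay, because all four compounds stand at a limit of the assay: the limit of > 5000 nM in this assay, at which 4 of the 4 values shown sit. The compounds shown leave open where each of the four truly lies in this assay, and whether the groups exchanged on the aromatic carbon separate them at all.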